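This account rests on a few compounds, and the source may have more. Where it says the series, first, only, none or still open, it means among the compounds named here.

Working notes on the series. In an ADME assay on KB cells (Homo sapiens) for cytotoxicity, with a stated time of 48 h (on this read-out higher numbers stand for weaker inhibition and lower numbers for stronger inhibition), compound 1 `CC1=CCC[C@](C)(CC/C(C)=C/CC2=C(O)C(=O)C=C(N[C@H](C(=O)O)[C@@H](C)O)C2=O)[C@@H]1C` gives > 10 ug/mL, which is a limit and not a number. Compound 2 `C=C1[C@H](C)CCC[C@]1(C)CC/C(C)=C/CC1=C(O)C(=O)C=C(N[C@H](C(=O)O)[C@@H](C)O)C1=O` gives > 10 ug/mL, also a limit. Going by the values given here, the series so far therefore offers only (the limit of > 10 ug/mL in this assay, at which 2 of the 2 values shown sit), and compound 1 has no exact position on the scale.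

Compound 3 `COC1=CC(=O)C(O)=C(C/C=C(\C)CC[C@@]2(C)CCC=C(C)[C@H]2C)C1=O` differs from compound 1 as follows: methoxy in place of (1-carboxy-2-hydroxypropyl)amino on a double-bonded ring carbon. In short, methoxy stands in place of (1-carboxy-2-hydroxypropyl)amino on a double-bonded ring carbon.

Among the compounds with values here, the only measured step is a step that the two limits leave unreadable from compound 1 to compound 2. It concerns the group on the saturated chain carbon, not the group exchanged here, and it provides no size to carry over. With compound 1 at > 10 ug/mL, there is room for a step only towards stronger inhibition to be read as a number, and compound 3 may equally return a limit. A modest move in that direction is expected, though this is a tentative judgement resting on the extent of the exchange alone. The expected step is an at least 1.6-fold lower number from compound 1 to compound 3 (0.22 log units; that floor lies within the scatter). The estimate for compound 3 is 6 ug/mL, with an expected range of 2 ug/mL to 20 ug/mL.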

Compound 3, half-maximal inhibitory concentration: > 10 ug/mL
Compound 3: only a limit was reported (the forecaster's own chance of this, stated with the estimate: 35%); middle value at least 1.6-fold (0.22 log units) from the limit.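

In this assay compound 3 gives > 10 ug/mL, which is a limit and not a number. The step between compound 1 and compound 3 therefore cannot be read, and the series stays at a single limit: the limit of > 10 ug/mL in this assay, at which 3 of the 3 values shown sit.

The compounds shown leave open how far either exchange, including methoxy in place of (1-carboxy-2-hydroxypropyl)amino, moves the read-out.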